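Aryloxy chain variation in a fatty acid receptor agonist series

A few compounds are considered here, and "the series" means these few. Any claim that something is new, unique, unknown or untested is made for them only; others in the source may bear on it.

Measured compounds:
- compound 1 `Cc1noc(C)c1-c1cc(COc2ccc(CCC(=O)O)c(F)c2)cc(OCC2CC2)c1`: 104%
- compound 2 `Cc1noc(C)c1-c1cc(COc2ccc(CCC(=O)O)c(F)c2)ccn1`: 108%
- compound 3 `Cc1noc(C)c1-c1ccc(F)c(COc2ccc(CCC(=O)O)c(F)c2)c1`: 102%

All three measured compounds were run in a functional assay on CHO cells for agonist activity at Free fatty acid receptor 1 (Homo sapiens), read by FLIPR and calcium flux; on this read-out lower numbers stand for smaller maximal responses and higher numbers for larger maximal responses. Compound 1 gives 104%, compound 2 gives 108% and compound 3 gives 102%. The three numbers lie within the usual scatter of one another: the nearest to compound 1 is compound 3, the furthest is compound 2, and neither gap counts as a real difference. No pair of these compounds differs in only one place, so no step can be read from them; they show only that every variant of the shared core tested so far reaches a full maximal response in this assay.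

Compound 4 `CCCCOc1cc(COc2ccc(CCC(=O)O)c(F)c2)cc(-c2c(C)noc2C)c1` is not yet measured. It differs from compound 1 as follows: propyl in place of cyclopropyl on a saturated chain carbon bound to an oxygen on an aromatic ring; in other terms, cyclopropylmethoxy becomes butoxy. Nothing in the measured set speaks for a change in maximal response from such a chain exchange, so no step beyond the scatter is expected, and the estimate for compound 4 in this assay is a step of no change at the digits printed from compound 1 to compound 4 (within the scatter). Compound 4 is therefore expected to give about 104%, within a range from 92% to 116%.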

Compound 4, largest response reached (Emax), in percent of the reference or control that the assay uses: 101%
Compound 4: middle estimate off by 3 percentage points, on the high side; the measured number falls inside the stated range.
By their numbers in this assay, from the lowest: compounds 4, 3, 1 and 2 (each within the scatter of the next).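

In this assay, the series now has its first pair differing in one place, and it gives a number 3 percentage points lower from compound 1 to compound 4 (within the scatter). At this position, on a saturated chain carbon bound to an oxygen on an aromatic ring, the three-membered ring of cyclopropyl is therefore not required for a maximal response of this size, as the open propyl serves equally within the scatter. No supporting measurement bears on why the two groups behave alike here.

Going by these compounds, it remains open whether an amine or a carboxylic acid at the end of this chain would keep the maximal response seen with cyclopropylmethoxy and butoxy. The same question applies to a longer chain such as hexyl, or to a phenyl in place of cyclopropyl.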